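From a five-membered to a six-membered ring

The source may hold more compounds than are shown below. What is called first, only, known or untested is meant among the compounds shown, and "the series" means these compounds.

In a functional assay on CCRF-CEM cells (Homo sapiens) for antiproliferative activity, read by cell counting, with a stated time of 2 days (a lower number here means a stronger inhibitor, a higher number a weaker inhibitor), compound 1 `COc1cc(C(=O)c2sc(N)nc2N)cc(OC)c1OC` gives 42000 nM. Compound 2 `COc1cc(C(=O)c2sc(N(C)Cc3ccccc3)nc2N)cc(OC)c1OC` gives > 200000 nM, which is a limit of the assay and not a number. Compound 3 `COc1cc(C(=O)c2sc(N3CCCC3)nc2N)cc(OC)c1OC` gives 320 nM, the lower of the two true numbers. Pyrrolidin-1-yl in place of amino brought a 130-fold lower number from compound 1 to compound 3 (2.12 log units; beyond the scatter), whereas benzyl(methyl)amino in place of amino brought an at least 4.7-fold higher number from compound 1 to compound 2 (0.67 log units; beyond the scatter). Compound 4 `COc1cc(C(=O)c2sc(N3CCCCC3)nc2N)cc(OC)c1OC` differs from compound 3 by a single change: piperidin-1-yl in place of pyrrolidin-1-yl on an aromatic carbon. Compound 4 keeps a non-aromatic ring, like compound 3 at 320 nM, so a moderate shift to a higher number is expected, well short of the size of an at least 620-fold lower number from compound 2 to compound 3 (2.79 log units; beyond the scatter). The expected step is a 2.8-fold higher number from compound 3 to compound 4 (0.45 log units; beyond the scatter). For compound 4 the estimated value is 900 nM, with an expected range of 200 nM to 6000 nM.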

Compound 4, half-maximal inhibitory concentration: 22000 nM
For compound 4 the middle estimate is 24-fold (1.39 log units) below the measured one; measured number above the stated range.
By their numbers in this assay, from the lowest: compound 3; then compounds 4 and 1 (each within the scatter of the next). At a limit, above all of these: compound 2.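

In this assay the six-membered ring of piperidin-1-yl in place of the five-membered ring of pyrrolidin-1-yl gives a 69-fold higher number from compound 3 to compound 4 (1.84 log units; beyond the scatter), so a non-aromatic ring here does not by itself bring a low number: ring size matters at this position. Piperidin-1-yl in place of amino gives a 1.9-fold lower number from compound 1 to compound 4 (0.28 log units; within the scatter), so compound 4 keeps none of the gain seen with compound 3. Piperidin-1-yl in place of benzyl(methyl)amino gives an at least 9.0-fold lower number from compound 2 to compound 4 (0.95 log units; beyond the scatter), a step read from a limit and not from a number: the limit of > 200000 nM in this assay, at which 1 of the 4 values shown sits.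

On these data alone, whether azetidin-1-yl or morpholin-4-yl at this position would sit nearer pyrrolidin-1-yl or piperidin-1-yl remains open.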